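The compounds below may be only part of what the source reports. "The series", "measured", "known", "first", "only" and "open" are said of these compounds alone.

Of the compounds shown here, two sharing one core have been measured in an assay on isolated protein for inhibition of kynurenine 3-monooxygenase (Homo sapiens), read by LC-MS; on this read-out higher numbers stand for weaker inhibition and lower numbers for stronger inhibition. Compound 1 `Clc1ccc(-c2cc(-n3cccn3)ncn2)cc1Cl` carries a five-membered aromatic ring with 2 nitrogen on the core. In this assay compound 1 reaches only the limit > 10000 nM, which is not a number. Compound 2 `O=c1[nH]ccn1-c1cc(-c2ccc(Cl)c(Cl)c2)ncn1` differs by a step that the two limits leave unreadable from compound 1 to compound 2, and this step cannot be read in size. In this assay compound 2 also reaches only the limit > 10000 nM. Both values therefore sit at the limit of > 10000 nM in this assay, at which 2 of the 2 values shown sit, so compound 2 stands at the weak end of what this assay reports.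

Compound 3 `Cn1ccn(-c2cc(-c3ccc(Cl)c(Cl)c3)ncn2)c1=O` is not yet measured. It differs from compound 2 by methyl in place of hydrogen on an aromatic nitrogen. Among the measured compounds shown here, no measured step covers this change, and the single step so far gives no readable size, so no direction beyond the scatter can be expected. Compound 3 is estimated at 15000 nM in this assay, between 4000 nM and 60000 nM, an expected step that the limit leaves unreadable from compound 2 to compound 3.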

Compound 3, half-maximal inhibitory concentration: > 10000 nM
Compound 3: only a limit was reported (the forecaster's own chance of this, stated with the estimate: 70%); the middle value is on the limit's open side.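

Compound 1, compound 2 and compound 3 all stop at a limit rather than a number, so none of the steps among them can be read in size: the limit of > 10000 nM in this assay, at which 3 of the 3 values shown sit.

The compounds shown leave open whether methyl in place of hydrogen, or any other change on the shared core, alters inhibition in this assay.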